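A few compounds are considered here, and "the series" means these few. Any claim that something is new, unique, unknown or untested is made for them only; others in the source may bear on it.

In an assay on HL-60 cells for inhibition of glutathione S-transferase P (Homo sapiens), read by spectrophotometry, tested at 20 uM (on this read-out higher numbers stand for more inhibition at the one concentration tested (going by the name of the read-out) and lower numbers for less inhibition), compound 1 `Cc1ccc2c(c1)C(=O)/C(=C/c1ccccc1)CN2CC(=O)O` gives 4.23%. Compound 2 `Cc1ccc2c(c1)C(=O)/C(=C/c1ccc(Cl)cc1)CN2CC(=O)O` differs by chloro in place of hydrogen on an aromatic carbon, and in this assay compound 2 gives 20.7%, a step of a number 16.5 percentage points higher from compound 1 to compound 2 (beyond the scatter). Compound 3 `Cc1cccc2c1N(CC(=O)O)C/C(=C\c1ccccc1)C2=O` has the same atoms as compound 1 joined differently; the difference between the two cores is not broken down here. In this assay compound 3 gives 27.9%, which lies within the scatter of compound 2. Compound 4 `Cc1cccc2c1N(CC(=O)O)C/C(=C\c1ccccc1Cl)C2=O` carries the same kind of change, (chloro in place of hydrogen on an aromatic carbon), but the chloro of compound 2 sits para to a large group while that of compound 4 sits ortho to a large group. The estimated step of a number 10.1 percentage points higher from compound 3 to compound 4 (beyond the scatter) is expected to be somewhat smaller because a number 16.5 percentage points higher from compound 1 to compound 2 (beyond the scatter) was measured at a different place. Compound 4 is expected to give 38%, likely between 20% and 58%.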

Compound 4, a percentage reported as inhibition, at one concentration (the size of the read-out at that concentration, not a potency): 51.9%
Compound 4: the middle estimate sits 13.9 percentage points below what was measured; low and high end bracket the measured number.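

In this assay chloro in place of hydrogen on an aromatic carbon gives a number 24 percentage points higher from compound 3 to compound 4 (beyond the scatter) and so goes the same way on the core of compound 3 as on the core of compound 1, by a similar amount: the same change on two cores in this assay, a number 16.5 percentage points higher (beyond the scatter) from compound 1 to compound 2 and a number 24 percentage points higher (beyond the scatter) from compound 3 to compound 4, 7.5 percentage points apart, within the scatter of two such steps. The change therefore carried over between these two cores. This rests on one pair per core, however, with the chloro ortho to a large group only in compound 4, so the data neither separate the core from the place nor show that the change would carry to any other core.

The compounds shown leave open how a methoxy or nitrile on the phenyl ring would compare with chloro. They also leave open what an amide in place of the carboxylic acid would do.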